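Chloro for methyl on the aryl ring: outlook for compound 4

The source may report more compounds than this note shows. Statements on the series, on what has been measured and on what is new or still open speak of the compounds shown alone.

Compound 1 `Cc1ccc(-c2cc(N)n(-c3cccc(Cl)c3)n2)cc1` and compound 2 `Nc1cc(-c2ccc(Cl)cc2)nn1-c1cccc(Cl)c1` share one core; compound 3 `Cc1ccc(-c2nn(-c3ccc(Br)cc3)c(/N=C/N(C)C)c2C=O)cc1` and compound 4 `CN(C)/C=N/c1c(C=O)c(-c2ccc(Cl)cc2)nn1-c1ccc(Br)cc1` share another. The difference between the two cores is not broken down here. In a functional assay on NPC-TW01 cells (Homo sapiens) for inhibition, read by MTT assay, with a stated time of 72 h (a higher number here means a weaker inhibitor of growth, a lower number a stronger inhibitor of growth), compound 1 gives > 100000 nM, a limit of the assay and not a number. Compound 2 likewise reaches only the limit > 100000 nM in this assay. Going by the values given here, compound 3 gives 6000 nM in this assay, the single number among the three values. The change chloro in place of methyl on an aromatic carbon yields a step that the two limits leave unreadable from compound 1 to compound 2, unreadable because of the limit of > 100000 nM in this assay, at which 2 of the 3 values shown sit. Compound 4 carries the same change, (chloro in place of methyl on an aromatic carbon), at a place described in identical words. Measured evidence on the size of this change is therefore absent. Compound 4 is expected to show a step of a 1.2-fold lower number from compound 3 to compound 4 (0.08 log units; within the scatter) in this assay, within the usual scatter. For compound 4 the estimated value in this assay is 5000 nM, between 2000 nM and 15000 nM.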

Compound 4, concentration for 50% growth inhibition: > 100000 nM
Compound 4 was reported as a limit (the forecaster's own chance of this, stated with the estimate: 5%); middle value at least 20-fold (1.30 log units) from the limit.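

In this assay, the change from 4-methylphenyl to 4-chlorophenyl on the core of compound 3 gives an at least 16-fold higher number from compound 3 to compound 4 (1.22 log units; beyond the scatter). Compound 4 stands at > 100000 nM, which is a limit of the assay and not a number. The same change on the core of compound 1 cannot be read, so these compounds do not show whether its effect carries from one core to the other, because of a single limit: the limit of > 100000 nM in this assay, at which 3 of the 4 values shown sit.

Open, from the compounds shown here alone, is whether fluoro or methoxy in place of methyl on that aromatic carbon would keep a measurable number on the core of compound 3. Also open, going by these compounds, is whether any compound on the core of compound 1 gives a number rather than a limit in this assay.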